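Phenoxymethyl added to the unsubstituted triazole benzhydryl

A few compounds are considered here, and "the series" means these few. Any claim that something is new, unique, unknown or untested is made for them only; others in the source may bear on it.

Measured so far in an assay on isolated protein for inhibition of Aromatase (Homo sapiens), read by fluorescence and colorimetric assay, with a stated time of 30 min; on this read-out higher numbers stand for weaker inhibition and lower numbers for stronger inhibition:
compound 1 `N#Cc1ccc(C(c2ccc(C#N)cc2)n2cc(COc3ccc([N+](=O)[O-])cc3)nn2)cc1`: 7730 nM
compound 2 `COc1ccc(OCc2cn(C(c3ccc(C#N)cc3)c3ccc(C#N)cc3)nn2)cc1`: 12200 nM
compound 3 `c1ccc(C(c2ccccc2)n2ccnn2)cc1`: 4580 nM

Compound 3 gives the lowest of the three numbers, but its gap to compound 1 lies within the scatter; only compound 2 stands beyond it. Compound 4 `c1ccc(OCc2cn(C(c3ccccc3)c3ccccc3)nn2)cc1` differs from compound 3 by phenoxymethyl in place of hydrogen on an aromatic carbon. Going by the values given here, no measured step isolates this change. The only step shown, a 1.6-fold higher number from compound 1 to compound 2 (0.20 log units; within the scatter), concerns the aryloxy substituent and is within the scatter. Compounds 1 and 2 carry aryloxymethyl groups and also two nitriles, so their higher numbers cannot be assigned to the aryloxymethyl alone. The expectation is therefore no step beyond the scatter, at most a modest rise: a 1.5-fold higher number from compound 3 to compound 4 (0.18 log units; within the scatter). Compound 4 is estimated at 7000 nM, range 2500 nM to 20000 nM.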

Compound 4, half-maximal inhibitory concentration: 31300 nM
Compound 4: middle estimate off by 4.5-fold (0.65 log units), on the low side, and the stated range ends below it.
By their numbers in this assay, from the lowest: compounds 3, 1 and 2 (each within the scatter of the next, the first and the last beyond it); then compound 4.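

In this assay, going by these compounds alone, phenoxymethyl in place of hydrogen on the aromatic carbon of the five-membered ring gives a 6.8-fold higher number from compound 3 to compound 4 (0.83 log units; beyond the scatter) and is the first step here to isolate this position. On the core of compound 3, this position therefore does not take phenoxymethyl without a loss of inhibition beyond the scatter. Nothing available explains the step.

As far as these compounds go, whether a smaller group here, such as methyl or hydroxymethyl, would hold the number of compound 3 remains open. Also open, from the compounds shown here alone, is whether the two nitriles of compounds 1 and 2 change what an aryloxymethyl group does at this position.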